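An aryl swap from compound 3 to compound 4

This account rests on a few compounds, and the source may have more. Where it says the series, first, only, none or still open, it means among the compounds named here.

Compound 1 `C=C[C@@](C)(/C=C/c1ccc(O)cc1)CC/C=C(\C)CO` gives > 36600 nM
Compound 2 `CCOC(=O)/C=C/c1cc(/C=C/[C@](C)(/C=C/c2ccc(OC)cc2)CCC=C(C)C)ccc1O` gives > 36600 nM
Compound 3 `C=C[C@@](C)(/C=C/c1ccc(Nc2ccc(OC)cc2)cc1)CCC=C(C)C` gives > 36600 nM

All three compounds were tested in an ADME assay on BJ cells (Homo sapiens) for cytotoxicity, with a stated time of 72 h (a higher number here means that more compound is needed for the effect, a lower number that less compound is needed), and none returned a number. Compound 3 stands at a limit (> 36600 nM) and not at a measured value. The results for compound 1 and compound 2 are limits too, so all three sit together (the limit of > 36600 nM in this assay, at which 3 of the 3 values shown sit) and cannot be ranked. Among the compounds with values here, no two of them differ in one place alone, so no measured step is available.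

Compound 4 `C=C[C@@](C)(/C=C/c1ccc(Nc2cc(F)c(F)c(F)c2)cc1)CCC=C(C)C` has not yet been measured in this assay. It carries 3,4,5-trifluorophenyl in place of 4-methoxyphenyl on a nitrogen on an aromatic ring, and the rest of the structure is unchanged.

The expectation rests on compound 3 and its limit (> 36600 nM), which is the same limit seen for every measured compound. The most likely outcome is that compound 4 also gives only a limit, and any number that did appear is expected to mean that less compound is needed. The estimated step of an at least 1.1-fold lower number from compound 3 to compound 4 (0.05 log units; that floor lies within the scatter) is expected to stay within the usual scatter. For compound 4 the estimated value is 32000 nM, with an expected range from 12000 nM to 36600 nM.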

Compound 4, half-maximal effective concentration: > 36600 nM
Compound 4 gave a limit, no number; the forecaster's own chance of this, stated with the estimate: 70%; middle value at least 1.1-fold (0.05 log units) from the limit.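

In this assay compound 4 gives > 36600 nM, which is a limit and not a number. Compound 3 also stands at a limit, so no step can be read between compound 3 and compound 4. The compounds shown leave open whether 3,4,5-trifluorophenyl in place of 4-methoxyphenyl alters cytotoxicity at all, and at what concentration any of them would show it: the limit of > 36600 nM in this assay, at which 4 of the 4 values shown sit.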